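The source may hold more compounds than are shown below. What is called first, only, known or untested is meant among the compounds shown, and "the series" means these compounds.

Compound 1 `O=C1Nc2ccc(OC(F)(F)F)cc2/C1=N/NC(=S)Nc1ccccc1` is the starting point of this step. In an ADME assay on RD cells (Homo sapiens) for cytotoxicity (a lower number here means that less compound is tolerated, a higher number that more compound is tolerated), compound 1 gives only a limit, > 25000 nM. Compound 2 `CCCNC(=S)N/N=C1\C(=O)Nc2ccccc21` gives a limit as well in this assay, namely > 25000 nM. Compound 3 `O=C1Nc2ccccc2/C1=N/NC(=S)N1CCCC1` likewise gives a limit in this assay, > 25000 nM. Among the measured compounds shown here, the step that the two limits leave unreadable from compound 2 to compound 3 cannot be read, and no measured step can be sized, because of the limit of > 25000 nM in this assay, at which 3 of the 3 values shown sit. The change to compound 4 `O=C1Nc2ccc(Br)cc2/C1=N/NC(=S)Nc1ccccc1` is bromo in place of trifluoromethoxy on an aromatic carbon. For the measured compounds named here, no measured step touches this position, so no change beyond the scatter is expected in this assay. Compound 4 is expected to give 30000 nM, with a range from 10000 nM to 100000 nM, most probably again reported only as a limit. The step that the limit leaves unreadable from compound 1 to compound 4 is therefore expected to be none beyond the scatter.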

Compound 4, half-maximal cytotoxic concentration: > 25000 nM
Compound 4: no number, only a limit; the forecaster's own chance of this, stated with the estimate: 85%; the middle value lies beyond the limit too.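

In this assay the step from compound 1 to compound 4 cannot be read: the limit of > 25000 nM in this assay, at which 4 of the 4 values shown sit. The compounds shown leave open at what concentration any of them becomes cytotoxic, and whether any change to the shared core shifts it.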